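Cyclobutyl Replaces Sulfonylbenzyl: Expected Cytotoxicity Shift

The source may hold more compounds than are shown below. What is called first, only, known or untested is meant among the compounds shown, and "the series" means these compounds.

Compound 2 `CS(=O)(=O)c1ccc(Cn2c(=O)n(Cc3nc4ccccc4n3CCCC#N)c3cnccc32)cc1` stands lowest of the two plain numbers in an ADME assay on HEp-2 cells (Homo sapiens) for cytotoxicity (on this read-out lower numbers stand for higher toxicity in this test and higher numbers for lower toxicity in this test), giving 1980 nM. Compound 1 `N#CCCCn1c(Cn2c(=O)n(Cc3ccc(C#N)cc3)c3ccncc32)nc2ccccc21` gives 36800 nM in this assay. Among the measured compounds shown here, the only measured step between compounds differing in one place is a 19-fold lower number from compound 1 to compound 2 (1.27 log units; beyond the scatter). Compound 3 `N#CCCCn1c(Cn2c(=O)n(C3CC3)c3ccncc32)nc2ccccc21` gives > 151000 nM; 109000 nM (2 entries) in this assay, with more than one entry. Compound 4 `N#CCCCn1c(Cn2c(=O)n(C3CCC3)c3ccncc32)nc2ccccc21` differs from compound 2 by cyclobutyl in place of 4-(methylsulfonyl)benzyl on an aromatic nitrogen. The step from compound 1 to compound 2 concerns the group that leaves here, the 4-(methylsulfonyl)benzyl, and it was large, yet it changes a substituent on that group rather than removing the group, so it bears only indirectly on the change to compound 4. Because compound 3, carrying cyclopropyl in the same place, shows (the several entries of compound 3 in this assay, > 151000 nM; 109000 nM (2 entries)), compound 4 is expected to move strongly upward in this assay, by a 51-fold higher number from compound 2 to compound 4 (1.70 log units; beyond the scatter). Compound 4 is therefore estimated at 100000 nM, within 30000 nM to 200000 nM.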

Compound 4, half-maximal cytotoxic concentration: > 258000 nM
Compound 4 was reported as a limit (the forecaster's own chance of this, stated with the estimate: 40%); middle value at least 2.5-fold (0.41 log units) away from the limit.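

In this assay, cyclobutyl in place of 4-(methylsulfonyl)benzyl on this aromatic nitrogen gives an at least 130-fold higher number from compound 2 to compound 4 (2.11 log units; beyond the scatter), and cyclobutyl in place of 4-cyanobenzyl on the same nitrogen gives an at least 7.0-fold higher number from compound 1 to compound 4 (0.84 log units; beyond the scatter). The earlier step changed only a substituent on the benzyl group, whereas these two steps replace the whole group, and both go to a higher number, whichever substituent the benzyl group carried. Compound 4 is reported only as a limit and not as a number, so the full size of both steps stays unknown: the limit of > 258000 nM in this assay, at which 1 of the 4 values shown sits.

The compounds shown leave open whether the higher numbers follow from losing the six-membered aromatic ring or from the presence of a small carbon ring. An unsubstituted benzyl group or an open butyl chain on this nitrogen would begin to separate the two.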